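Lengthening the alkyl arm of a hydroxyurea alkyne

This account rests on a few compounds, and the source may have more. Where it says the series, first, only, none or still open, it means among the compounds named here.

Compound 1: `C[C@H](C#Cc1cccc(C(=O)NCc2ccccc2C(F)(F)F)c1)N(O)C(N)=O`, 600 nM
Compound 2: `CC(C#Cc1cccc(C(=O)NCCC(c2ccccc2)c2ccc(OC(F)(F)F)cc2)c1)N(O)C(N)=O`, 110 nM
Compound 3: `C[C@H](C#Cc1cccc(C(=O)NCCC(c2ccccc2)c2ccc(Cl)c(Cl)c2)c1)N(O)C(N)=O`, 96 nM

In an assay for inhibition of Polyunsaturated fatty acid 5-lipoxygenase (Homo sapiens), read by HPLC, with stated times of 15 min and 10 min (on this read-out lower numbers stand for stronger inhibition and higher numbers for weaker inhibition), compound 1 gives 600 nM, the highest of the three numbers and thus the weakest inhibition shown. Compound 2 gives 110 nM and compound 3 gives 96 nM, both beyond the scatter from compound 1, while the two of them lie within the scatter of each other.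

Compound 4, `CCCC(C#Cc1cccc(C(=O)NCc2ccccc2C(F)(F)F)c1)N(O)C(N)=O`, differs from compound 1 by a single change: 1-(carbamoyl(hydroxy)amino)butyl in place of 1-(carbamoyl(hydroxy)amino)ethyl on a triple-bonded carbon. For the measured compounds named here, no measured pair isolates this change, so the account rests on expectation alone. The step from compound 1 to compound 4 is expected to be small, a 1.3-fold lower number from compound 1 to compound 4 (0.12 log units; within the scatter), not clearly beyond the scatter in either direction. Compound 4 is therefore estimated at 450 nM, with a range from 150 nM to 1400 nM.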

Compound 4, half-maximal inhibitory concentration: 300 nM
Compound 4: middle estimate off by 1.5-fold (0.18 log units), on the high side; measured number inside the range.
By their numbers in this assay, from the lowest: compounds 3 and 2 (each within the scatter of the next); then compounds 4 and 1 (each within the scatter of the next).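

In this assay, 1-(carbamoyl(hydroxy)amino)butyl in place of 1-(carbamoyl(hydroxy)amino)ethyl on a triple-bonded carbon gives a 2.0-fold lower number from compound 1 to compound 4 (0.30 log units; within the scatter), so lengthening this chain shifts the number by no more than the scatter. The earlier compounds shown here all carried the ethyl form and could not show this tolerance. The step also gives up the defined stereocentre of compound 1, and no evidence is available to explain the result.

Going by these compounds, whether a longer chain such as hexyl, or a phenyl group, would be tolerated at this position remains open. So does whether the butyl form would behave alike with the amide groups of compound 2 and compound 3.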